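The source may report more compounds than this note shows. Statements on the series, on what has been measured and on what is new or still open speak of the compounds shown alone.

In an ADME assay on MT4 cells (Homo sapiens) for cytotoxicity, read by MTT assay, with a stated time of 4 days (on this read-out higher numbers stand for lower toxicity in this test and lower numbers for higher toxicity in this test), the series so far reads as follows:

compound 1 `CCOc1ccc(/C=N/NC(=O)COc2cccc3ccccc23)cc1O` gives 6.23 ug/mL
compound 2 `O=C(COc1cccc2ccccc12)N/N=C/c1ccc(O)cc1` gives 26.5 ug/mL
compound 3 `C/C(=N\NC(=O)COc1cccc2ccccc12)c1cccc([N+](=O)[O-])c1` gives 12.1 ug/mL

Compound 3 (12.1 ug/mL) cannot be told apart from compound 1 (6.23 ug/mL) within the usual scatter. Compound 2 (26.5 ug/mL) stands higher than compound 3, beyond the scatter, and so shows the lower toxicity in this test.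

The next compound is compound 4 `C/C(=N\NC(=O)COc1cccc2ccccc12)c1ccc(Cl)cc1`, which carries 4-chlorophenyl in place of 3-nitrophenyl on a carbon with a double bond to nitrogen.

Among the measured compounds shown here, no measured pair differs in one place only, so the data give no direct guide to this exchange. The best anchor is compound 3 at 12.1 ug/mL, which also carries the same kind of carbon with a double bond to nitrogen and a saturated chain carbon. In this assay no step beyond the scatter is expected, and no direction is favoured with any confidence. The estimate means a 1.2-fold lower number from compound 3 to compound 4 (0.08 log units; within the scatter) as the expected step. For compound 4 the expected value is 10 ug/mL, with an estimated range of 3.5 ug/mL to 32 ug/mL in this test.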

Compound 4, half-maximal cytotoxic concentration: 4.07 ug/mL
Beside the measured number, compound 4's estimate is 2.5-fold (0.39 log units) above it; measured number inside the range.
By their numbers in this assay, from the lowest: compounds 4, 1 and 3 (each within the scatter of the next, the first and the last beyond it); then compound 2.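

Among the compounds shown here, compound 3 and compound 4 form the first pair that differs in one place only, so the group on the carbon with a double bond to nitrogen can now be read directly in this assay. The exchange of 3-nitrophenyl for 4-chlorophenyl gives a 3.0-fold lower number from compound 3 to compound 4 (0.47 log units; beyond the scatter), which stands for higher toxicity in this test and shows that this place is not silent on this read-out, although one modest step from a single pair sets no trend. The exchange also replaces a group counted with hydrogen-bond acceptors by one counted with none, but nothing available gives a reason for the step.

The exchange alters the substituent and the number of its place on the ring together, so 3-chlorophenyl and 4-nitrophenyl on the same carbon would be needed to separate the two. Also open, on these data alone, is where unsubstituted phenyl or 4-aminophenyl would fall at this place, and so whether the step belongs to the gain of chlorine, the loss of the nitro group, or both.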